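A few compounds are considered here, and "the series" means these few. Any claim that something is new, unique, unknown or untested is made for them only; others in the source may bear on it.

Three compounds built on one shared core have been examined in a functional assay on EA.hy 926 cells (Homo sapiens) for cytotoxicity, read by MTT assay, with stated times of 24 h and 12 h, tested at 50 uM; a lower number here means a weaker effect, a higher number a stronger effect of the compound at the concentration tested. Compound 1 `COc1ccc(OC(=O)c2nc(C)c(C)nc2C)c(/C=C/C(=O)O)c1` gives 62.9%, compound 2 `COc1ccc(/C=C/C(=O)O)cc1OC(=O)c1nc(C)c(C)nc1C` gives 160%, and compound 3 `CCOC(=O)/C=C/c1ccc(OC)c(OC(=O)c2nc(C)c(C)nc2C)c1` gives 89%. Compound 1 and compound 2 contain the same atoms joined differently; the difference between the two cores is not broken down here. Compound 3 differs from compound 2 by ethyl in place of hydrogen on an oxygen next to a carbonyl group, a change that produced a number 71 percentage points lower from compound 2 to compound 3 (beyond the scatter). Compound 4 `CCOC(=O)/C=C/c1cc(OC)ccc1OC(=O)c1nc(C)c(C)nc1C` has not yet been measured; it differs from compound 1 by ethyl in place of hydrogen on an oxygen next to a carbonyl group, the same change at the same place. Because compound 1 already gives only 62.9%, a drop as deep as a number 71 percentage points lower from compound 2 to compound 3 (beyond the scatter) cannot be repeated in full, so a smaller step, a number 22.9 percentage points lower from compound 1 to compound 4 (beyond the scatter), is expected. Compound 4 is therefore estimated at 40%, within a range from 15% to 70%.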

Compound 4, a percentage reported as activity, at one concentration (the size of the read-out at that concentration, not a potency): 27.8%
Estimate against measurement, compound 4: 12.2 percentage points above, within the range that was stated.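

In this assay, ethyl in place of hydrogen on an oxygen next to a carbonyl group again gave a lower number, with a number 35.1 percentage points lower from compound 1 to compound 4 (beyond the scatter). The direction of the change was therefore shared by both cores, but its size did not carry over from one to the other: the same change on two cores in this assay, a number 71 percentage points lower (beyond the scatter) from compound 2 to compound 3 and a number 35.1 percentage points lower (beyond the scatter) from compound 1 to compound 4, 35.9 percentage points apart, beyond the scatter of two such steps. These two pairs show only this shared direction and a gap in size; they do not explain the gap or give a rule for any further core.

The compounds shown leave open whether a methyl group or a longer chain on that oxygen would lower the number in the same way. They also leave open how an amide in place of the ester would behave on either core.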